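The compounds below may be only part of what the source reports. "The series", "measured", "known", "first", "only" and "open" are said of these compounds alone.

Three compounds share one core and differ only in the group attached to an aromatic carbon of that core. Compound 1 `COC(=O)c1ccccc1-c1cnc(C(=O)CCCCCCc2ccccc2)o1` gives 60 nM in an assay (Rattus norvegicus) for inhibition of Fatty-acid amide hydrolase 1 (Homo sapiens); a higher number here means a weaker inhibitor, a lower number a stronger inhibitor. Compound 2 `Cc1cccnc1-c1cnc(C(=O)CCCCCCc2ccccc2)o1` gives 15 nM in this assay, and compound 3 `COC(=O)c1ccc(-c2cnc(C(=O)CCCCCCc3ccccc3)o2)nc1` gives 3.5 nM. Among these three numbers compound 2 stands second highest: compound 1 sits above it by a margin beyond the scatter, and compound 3 sits below it by a margin that is likewise beyond the scatter. So compound 2 is neither the strongest nor the weakest inhibitor of the three.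

The unmeasured compound 4 `CN1CCN(C(=O)c2cnc(C(=O)CCCCCCc3ccccc3)o2)CC1` takes compound 2 and makes one change: (4-methylpiperazin-1-yl)carbonyl in place of 3-methylpyridin-2-yl on an aromatic carbon. The group that leaves is aromatic and carries one acceptor; the group that enters is a non-aromatic ring joined through a carbonyl and carries two acceptors. Among the compounds with values here, no measured pair shows the effect of such a swap, so the direction can only be guessed from the fact that all three measured compounds keep an aromatic group at this place. He expects compound 4 to be a weaker inhibitor than compound 2, with a step of a 4.0-fold higher number from compound 2 to compound 4 (0.60 log units; beyond the scatter) in this assay, roughly comparable in size to the gap between compound 2 and compound 1. His estimate for compound 4 in this assay is 60 nM, with a range from 15 nM to 300 nM.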

Compound 4, inhibition constant: 80 nM
Compound 4: the middle estimate sits 1.3-fold (0.12 log units) below what was measured; measured number inside the range.
By their numbers in this assay, from the lowest: compound 3; then compound 2; then compounds 1 and 4 (each within the scatter of the next).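

In this assay, putting (4-methylpiperazin-1-yl)carbonyl in place of 3-methylpyridin-2-yl gives a 5.3-fold higher number from compound 2 to compound 4 (0.73 log units; beyond the scatter), a modest step beyond the scatter. The earlier compounds shown here all kept an aromatic ring at this place, next to the ring oxygen, so they could not show what happens without one. The new result shows that a non-aromatic ring joined through a carbonyl still leaves an inhibitor in the range already seen, since compound 4 at 80 nM and compound 1 at 60 nM lie within the scatter of each other, though compound 3 at 3.5 nM remains well apart from both.

Nothing given here bears on why the number rises from compound 2 to compound 4. Going by these compounds, a single swap changes the ring, the carbonyl link and the acceptor count together, so it remains open which of these goes with the step, and a morpholine amide, a carboxylic acid or an unsubstituted phenyl at this place would be needed to separate them.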